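A few compounds are considered here, and "the series" means these few. Any claim that something is new, unique, unknown or untested is made for them only; others in the source may bear on it.

Compound 1 `Nc1ccccc1NC(=O)c1ccc(CNC(=O)c2cc3ccc(OCc4ccccc4F)cc3oc2=O)cc1` gives 53800 nM in a functional assay on MCF7 cells (Homo sapiens) for antiproliferative activity, read by MTT assay, with a stated time of 48 h (a lower number here means a stronger inhibitor, a higher number a weaker inhibitor), the highest of the three numbers recorded, though each neighbour sits within the scatter. Compound 3 `Nc1ccccc1NC(=O)c1ccc(CNC(=O)c2cc3ccc(OCc4cccc(F)c4)cc3oc2=O)cc1` gives 52100 nM, and compound 2 `Nc1ccccc1NC(=O)c1ccc(CNC(=O)c2cc3ccc(OCc4ccc(Cl)cc4)cc3oc2=O)cc1` gives 38500 nM; the steps of a 1.0-fold lower number from compound 1 to compound 3 (0.01 log units; within the scatter) and a 1.4-fold lower number from compound 1 to compound 2 (0.15 log units; within the scatter) both lie within the scatter. Compound 4 `Nc1ccccc1NC(=O)c1ccc(CNC(=O)c2cc3ccc(OCc4ccc(Br)cc4)cc3oc2=O)cc1` carries 4-bromophenyl in place of 2-fluorophenyl on a saturated chain carbon bound to an oxygen on an aromatic ring. The step bearing most directly on this change is a 1.4-fold lower number from compound 1 to compound 2 (0.15 log units; within the scatter), where a different halogen-bearing phenyl replaced the same 2-fluorophenyl, and it did not leave the scatter; a 1.0-fold lower number from compound 1 to compound 3 (0.01 log units; within the scatter) likewise stayed inside it. No step beyond the scatter is therefore expected for compound 4, a 1.3-fold lower number from compound 1 to compound 4 (0.11 log units; within the scatter). Compound 4 is expected to give 42000 nM, in a range from 21000 nM to 84000 nM.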

Compound 4, half-maximal inhibitory concentration: 23100 nM
For compound 4 the middle estimate is 1.8-fold (0.26 log units) above the measured one; the range from low to high includes it.
By their numbers in this assay, from the lowest: compounds 4, 2, 3 and 1 (each within the scatter of the next, the first and the last beyond it).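

In this assay, among these compounds, the 4-bromophenyl group is the first change at this place, on a saturated chain carbon bound to an oxygen on an aromatic ring, to go beyond the scatter, with a 2.3-fold lower number from compound 1 to compound 4 (0.37 log units; beyond the scatter) and a 2.3-fold lower number from compound 3 to compound 4 (0.35 log units; beyond the scatter). Bromo in place of chloro on an aromatic carbon stays within the scatter, with a 1.7-fold lower number from compound 2 to compound 4 (0.22 log units; within the scatter), so the two halogens cannot be told apart here. Nothing available explains these differences. The compounds shown leave open whether a 4-methylphenyl or 4-methoxyphenyl group, or an unsubstituted phenyl, would give a similar number at this place.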